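Methoxy in Place of Methylcarbamoyl: Expected Cytotoxicity

The source may report more compounds than this note shows. Statements on the series, on what has been measured and on what is new or still open speak of the compounds shown alone.

Three compounds on a shared core were examined in a functional assay on MT2 cells (Homo sapiens) for cytotoxicity, read by XTT assay, with a stated time of 3 days; on this read-out lower numbers stand for higher toxicity in this test and higher numbers for lower toxicity in this test. Compound 1 `COc1cnc(-c2cnccn2)c2[nH]cc(C(=O)C(=O)N3CCN(C(=O)c4ccccn4)[C@@H](C)C3)c12` reaches only a limit of the assay, >= 267000 nM. Compound 2 `COc1cnc(-n2ccc(CN(C)C)n2)c2[nH]cc(C(=O)C(=O)N3CCN(C(=O)c4ccccc4)[C@H](C)C3)c12` also gives only a limit, > 300000 nM. Compound 3 `CNC(=O)c1ncn(-c2ncc(OC)c3c(C(=O)C(=O)N4CCN(C(=O)c5ccccc5)CC4)c[nH]c23)n1` likewise stops at a limit, > 300000 nM. Compound 3 therefore stands at the limit of > 300000 nM in this assay, at which 2 of the 3 values shown sit. Going by the values given here, the one remaining value stands at the limit of >= 267000 nM in this assay, at which 1 of the 3 values shown sits. None of the three shows measurable toxicity within the tested range.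

Compound 4 `COc1ncn(-c2ncc(OC)c3c(C(=O)C(=O)N4CCN(C(=O)c5ccccc5)CC4)c[nH]c23)n1` differs from compound 3 by methoxy in place of methylcarbamoyl on an aromatic carbon. Among the compounds with values here, no pair of measured compounds differing in one place is available, so the size of this step has no measured counterpart. Since compound 3 sits at the limit of > 300000 nM in this assay, at which 2 of the 3 values shown sit, compound 4 is expected to remain at that limit as well. The expected step from compound 3 to compound 4 in this assay is a number no higher from compound 3 to compound 4 (the limit leaves the size open), which is no change beyond the scatter. Compound 4 is thus estimated at 300000 nM, within a range from 150000 nM to 600000 nM.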

Compound 4, half-maximal cytotoxic concentration: 285000 nM
For compound 4 the middle estimate is 1.1-fold (0.02 log units) above the measured one; the measured number falls inside the stated range.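

In this assay, methoxy on the aromatic carbon between two ring nitrogen atoms gives compound 4 a measured number instead of a limit, 285000 nM. The exchange of methylcarbamoyl for methoxy reads as an at least 1.0-fold lower number from compound 3 to compound 4 (0.02 log units; that floor lies within the scatter), so this change at this position shows no step beyond the scatter, although the methoxy group has fewer heavy atoms and no hydrogen-bond donor. The size of the step has only that floor, since the value of compound 3 is only a limit: the limit of > 300000 nM in this assay, at which 2 of the 4 values shown sit.

Going by these compounds, what remains open is how far the true value of compound 3 lies from that of compound 4. Also open, on these data alone, is whether an amine or a carboxylic acid on this same carbon would give a number in this assay or stop at a limit.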